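The source may report more compounds than this note shows. Statements on the series, on what has been measured and on what is new or still open speak of the compounds shown alone.

In a functional assay on PC-3 cells (Homo sapiens) for antiproliferative activity, read by MTT assay, with a stated time of 48 h (on this read-out higher numbers stand for weaker inhibition and lower numbers for stronger inhibition), compound 1 `O=C(Nc1ccccc1)Nc1nnc(Sc2ncnc3scc(-c4ccncc4)c23)s1` gives 5700 nM, and compound 2 `O=C(Nc1cccc(Cl)c1)Nc1nnc(Sc2ncnc3scc(-c4ccncc4)c23)s1` gives 8000 nM. The step of a 1.4-fold higher number from compound 1 to compound 2 (0.15 log units; within the scatter) lies within the scatter, so compound 2 holds the higher of the two numbers without standing apart from compound 1. Compound 3 `O=C(Nc1cccc(F)c1)Nc1nnc(Sc2ncnc3scc(-c4ccncc4)c23)s1` differs from compound 2 by fluoro in place of chloro on an aromatic carbon. Going by the values given here, the only measured step that bears on a change at this aromatic carbon, a 1.4-fold higher number from compound 1 to compound 2 (0.15 log units; within the scatter), was small, so no step beyond the scatter is expected in this assay. The expected step is a 1.2-fold lower number from compound 2 to compound 3 (0.09 log units; within the scatter). For compound 3 the estimate is 6500 nM, with a range from 3000 nM to 14000 nM.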

Compound 3, half-maximal inhibitory concentration: 6600 nM
Compound 3: middle estimate off by 1.0-fold (0.01 log units), on the low side; low and high end bracket the measured number.
By their numbers in this assay, from the lowest: compounds 1, 3 and 2 (each within the scatter of the next).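

Fluoro in place of chloro gives a 1.2-fold lower number from compound 2 to compound 3 (0.08 log units; within the scatter), and fluoro in place of hydrogen gives a 1.2-fold higher number from compound 1 to compound 3 (0.06 log units; within the scatter). In this assay, this aromatic carbon has now carried hydrogen, chloro and fluoro with no step beyond the scatter, so the exchange among these three leaves the number effectively unchanged. No evidence on the cause of this flat result is at hand. The compounds shown leave open whether an amine, a carboxylic acid or a methoxy group at this carbon would move the number beyond the scatter.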